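Flipping One Ring Centre in an Antinociceptive Series

This account rests on a few compounds, and the source may have more. Where it says the series, first, only, none or still open, it means among the compounds named here.

Of the compounds shown here, three have been measured in a functional assay on the whole organism with Mus musculus as the target, in the writhing test; a lower number here means that less compound is needed, a higher number that more compound is needed for the effect. Compound 1 `CCCCSc1nsnc1[C@@H]1CN2CCC[C@@H]1C2` gives 0.19 mg/kg. Compound 2 `FC(F)(F)CCCSc1nsnc1[C@H]1CN2CCC[C@H]1C2` gives 0.1 mg/kg, the lowest of the three numbers, yet its gaps to compound 3 `CCCCSc1nsnc1C1=CCCNC1` with 0.14 mg/kg and to compound 1 both lie within the usual scatter of this kind of test, so the three compounds cannot be set in order against one another on these data. Compound 1 and compound 2 carry their ring stereocentres with opposite drawn configurations and still land close together, which gives no sign that the drawn configuration decides the result here.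

Compound 4 `FC(F)(F)CCCSc1nsnc1[C@H]1CN2CCC[C@@H]1C2` is the untested member. Against compound 2 the difference is the two compounds have the same atoms and bonds; at least one stereo element is drawn with a configuration in one of them and without one in the other: 1 of 3 stereo elements differ; a stereocentre at a saturated ring carbon is drawn R in compound 2 and S in compound 4. Among the measured compounds shown here, nothing leaves and nothing enters; only one saturated ring carbon is drawn the other way round.

For the measured compounds named here, with no measured pair of this kind to lean on, a modest rise in the dose is expected for compound 4 relative to compound 2, one that may well stay inside the scatter, and the step from compound 2 to compound 4 is expected to be about a 3.0-fold higher number from compound 2 to compound 4 (0.48 log units; beyond the scatter). In this assay compound 4 is expected to need roughly 0.3 mg/kg, plausibly between 0.08 mg/kg and 1.2 mg/kg.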

Compound 4, dose for half-maximal effect: 1.8 mg/kg
Compound 4: middle estimate off by 6.0-fold (0.78 log units), on the low side, and the stated range ends below it.
By their numbers in this assay, from the lowest: compounds 2, 3 and 1 (each within the scatter of the next); then compound 4.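

Turning one saturated ring carbon from R to S, with no atom added or removed, gives an 18-fold higher number from compound 2 to compound 4 (1.26 log units; beyond the scatter) in this assay, a large step that lies beyond the scatter. Among the compounds shown here, the earlier compounds could not show this: compounds 1 and 2 differ in more than one place, so their closeness said nothing about any single centre, whereas here the configuration at this one carbon is the only change between the structures. The one thing on record that bears on this step is the stereo difference itself, and it tells where the change lies, not how it acts: the fact that one of compounds 2 and 4 is drawn with a defined configuration and the other without, at the place where they differ

As far as these compounds go, it remains open whether flipping this centre would cost as much in compound 1, or with a different side chain such as a hexyl chain or a benzyl group in place of the fluorinated one. From the compounds shown here alone, the other stereo elements also remain untested on their own, so the data cannot say whether turning either of them, or all of them together, would raise the dose in the same way.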